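Swapping a furan for a thiophene on a purine-free reading

This account rests on a few compounds, and the source may have more. Where it says the series, first, only, none or still open, it means among the compounds named here.

Compound 1 `COc1ccccc1-c1ccc(CNc2nc(NC3CCC(N)CC3)nc3c2ncn3C2CCCC2)cc1` gives 150 nM
Compound 2 `NC1CCC(Nc2nc(NCc3ccc(-c4cccc(F)c4)cc3)c3ncn(C4CCCC4)c3n2)CC1` gives 211 nM
Compound 3 `NC1CCC(Nc2nc(NCc3ccc(-c4ccco4)cc3)c3ncn(C4CCCC4)c3n2)CC1` gives 102 nM

All three values come from a functional assay on HOS cells (Homo sapiens) for inhibition, with a stated time of 72 h (on this read-out lower numbers stand for stronger inhibition and higher numbers for weaker inhibition), and can be compared directly. Compound 3 stands at 102 nM on this scale. Its place rests on two comparisons, with a 2.1-fold lower number from compound 2 to compound 3 (0.32 log units; beyond the scatter) as the one gap that clears the scatter and a 1.5-fold lower number from compound 1 to compound 3 (0.17 log units; within the scatter) as a gap that does not, so compound 1 and compound 3 cannot be told apart.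

Compound 4 `NC1CCC(Nc2nc(NCc3ccc(-c4ccsc4)cc3)c3ncn(C4CCCC4)c3n2)CC1` differs from compound 3 in one place (thiophen-3-yl in place of furan-2-yl on an aromatic carbon): thiophen-3-yl in place of furan-2-yl on an aromatic carbon, para to a large group. Within the data shown here, no measured pair makes this exact swap, and no thiophene has been tested yet. The closest guide is what other swaps at this same place have done. The change a 1.4-fold higher number from compound 1 to compound 2 (0.15 log units; within the scatter) stayed within the scatter, and the change a 2.1-fold lower number from compound 2 to compound 3 (0.32 log units; beyond the scatter) only just passed it. So no step beyond the scatter is expected in this assay for this change, in either direction. The estimated step is a 1.2-fold higher number from compound 3 to compound 4 (0.09 log units; within the scatter) in size, a small one. For compound 4 the expected value is 125 nM with an estimated range from 60 nM to 260 nM on this test.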

Compound 4, half-maximal inhibitory concentration: 120 nM
The estimate for compound 4 lay 1.0-fold (0.02 log units) above the measured number, within the range that was stated.
By their numbers in this assay, from the lowest: compounds 3, 4, 1 and 2 (each within the scatter of the next, the first and the last beyond it).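

In this assay the first thiophene at this place reads the same as the furan, with a 1.2-fold higher number from compound 3 to compound 4 (0.07 log units; within the scatter), so this swap of ring leaves the result unchanged as far as the assay can tell. Among these compounds, compound 4 also cannot be told apart from either compound carrying a substituted phenyl ring, with a 1.8-fold lower number from compound 2 to compound 4 (0.25 log units; within the scatter) and a 1.3-fold lower number from compound 1 to compound 4 (0.10 log units; within the scatter), which shows that a five-membered ring at this place does not by itself set a compound apart; the one exception is compound 3 against compound 2, at a 2.1-fold lower number from compound 2 to compound 3 (0.32 log units; beyond the scatter). No measurement offered here explains why the two rings read alike.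

This swap changes both the hetero atom and the ring carbon that carries the link, so the compounds shown leave open what each change does alone, which thiophen-2-yl or furan-3-yl could separate. Also open, as far as these compounds go, is whether this place accepts anything other than an aromatic ring, such as an amine, a carboxylic acid or a longer chain.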